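Compound 2 to compound 3: a further chloro group

A few compounds are considered here, and "the series" means these few. Any claim that something is new, unique, unknown or untested is made for them only; others in the source may bear on it.

In an ADME assay on HaCaT cells (Homo sapiens) for cytotoxicity, read by MTT assay, with a stated time of 48 h (a lower number here means a stronger inhibitor, a higher number a weaker inhibitor), compound 2 (`COc1ccc(-c2nn(-c3ccccc3)cc2-c2nc3cc(Cl)ccc3[nH]2)cc1`) reads > 50000 nM as a limit of the assay and not a number. For the measured compounds named here, compound 1 (`Fc1ccc(-c2nn(-c3ccccc3)cc2-c2nc3cc(Cl)c(Cl)cc3[nH]2)cc1`) gives 44600 nM in this assay and supplies the only true number so far.

Compound 3 (`COc1ccc(-c2nn(-c3ccccc3)cc2-c2nc3cc(Cl)c(Cl)cc3[nH]2)cc1`) departs from compound 2 by chloro in place of hydrogen on an aromatic carbon in one place: chloro in place of hydrogen on an aromatic carbon, ortho to a chloro group. Going by the values given here, no step between measured compounds gives a size for this change. The expectation rests on compound 1 at 44600 nM in this assay, since it also carries this chloro group.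

The expected step is an at least 1.1-fold lower number from compound 2 to compound 3 (0.04 log units; that floor lies within the scatter) as an estimate, small and toward a lower number, with nothing beyond the scatter expected. For compound 3 the estimated value is 45000 nM with an expected range of 25000 nM to 75000 nM in this assay, and a report as a limit remains possible.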

Compound 3, half-maximal inhibitory concentration: > 50000 nM
Compound 3 gave a limit, no number; the forecaster's own chance of this, stated with the estimate: 45%; middle value at least 1.1-fold (0.04 log units) away from the limit.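

The step for the further chloro group, ortho to a chloro group, cannot be read in this assay because both of its ends are limits: the limit of > 50000 nM in this assay, at which 2 of the 3 values shown sit. Compound 3 reads > 50000 nM, a limit of the assay and not a number, so adding this chloro group to the methoxy compound brings no number into range. With both chloro groups in place, methoxy in place of fluoro on an aromatic carbon gives an at least 1.1-fold higher number from compound 1 to compound 3 (0.04 log units; that floor lies within the scatter), which fixes no true size for that change.

On these data alone, whether the further chloro group shifts the reading at all remains open, as does the size of the methoxy-for-fluoro step. Also open, as far as these compounds go, is how an amine or a carboxylic acid in place of the methoxy group would read in this assay.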